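Hydroxy in place of pyridin-3-yl on the amide nitrogen

The source may report more compounds than this note shows. Statements on the series, on what has been measured and on what is new or still open speak of the compounds shown alone.

Three compounds share one core and differ only in the group carried on the amide-type nitrogen. Compound 1 `Cc1ccc(OCC(=O)N(Cc2cccs2)c2ncccn2)cc1` carries pyrimidin-2-yl there and, in an assay on HEK293 cells for agonist activity at transient receptor potential cation channel subfamily M member 8 (Homo sapiens), read by fluorescence and calcium flux, with a stated time of 15 min (a higher number here means that more compound is needed for the effect, a lower number that less compound is needed), compound 1 gives 3700 nM. Compound 2 `Cc1ccc(OCC(=O)N(Cc2cccs2)C(C)C)cc1` carries isopropyl and gives 70 nM. Compound 3 `Cc1ccc(OCC(=O)N(Cc2cccs2)c2cccnc2)cc1` carries pyridin-3-yl and gives 198 nM, which places it second highest of the three numbers, with a 19-fold lower number from compound 1 to compound 3 (1.27 log units; beyond the scatter) and a 2.8-fold higher number from compound 2 to compound 3 (0.45 log units; beyond the scatter).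

Compound 4 `Cc1ccc(OCC(=O)N(O)Cc2cccs2)cc1` is the next step from compound 3: hydroxy in place of pyridin-3-yl on an amide-type nitrogen. The measured steps that bear on this change are those altering the same nitrogen, namely a 53-fold lower number from compound 1 to compound 2 (1.72 log units; beyond the scatter), a 19-fold lower number from compound 1 to compound 3 (1.27 log units; beyond the scatter) and a 2.8-fold higher number from compound 2 to compound 3 (0.45 log units; beyond the scatter). They show that the group on this nitrogen moves the number strongly, yet none of them exchanges an aromatic ring for a single hydroxy carrying a hydrogen-bond donor, so the direction is not settled by the data.

Given that every measured exchange here shifted the number well beyond the scatter, a sizeable shift is expected again, with a higher number judged more likely than a lower one; the expected step is a 7.6-fold higher number from compound 3 to compound 4 (0.88 log units; beyond the scatter). For compound 4 the estimate is 1500 nM, within a range of 200 nM to 10000 nM.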

Compound 4, half-maximal effective concentration: 8000 nM
Estimate against measurement, compound 4: 5.3-fold (0.73 log units) below, and the stated range covers the measured number.
By their numbers in this assay, from the lowest: compound 2; then compound 3; then compound 1; then compound 4.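

In this assay, hydroxy in place of pyridin-3-yl gives a 40-fold higher number from compound 3 to compound 4 (1.61 log units; beyond the scatter), and hydroxy in place of isopropyl gives a 110-fold higher number from compound 2 to compound 4 (2.06 log units; beyond the scatter), so among these four compounds, having no ring on this nitrogen does not by itself keep the number low: isopropyl, also without a ring, gives the lowest number and hydroxy the highest. Hydroxy also ends above the previous highest group, pyrimidin-2-yl, with a 2.2-fold higher number from compound 1 to compound 4 (0.33 log units; beyond the scatter), which means that the single oxygen-bearing group is the poorest of the four on this nitrogen, even though the other three differ widely from one another. No measurement shown here gives a reason for these shifts.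

From the compounds shown here alone, how methoxy or a longer chain such as butyl would compare on this nitrogen remains open, and with it the question of whether the hydrogen-bond donor of hydroxy goes with the high number. Also open, going by these compounds, is whether phenyl, a six-membered aromatic ring with no nitrogen, would fall nearer to pyridin-3-yl or to pyrimidin-2-yl.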